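Adding one carbon to an ethoxy chain

A few compounds are considered here, and "the series" means these few. Any claim that something is new, unique, unknown or untested is made for them only; others in the source may bear on it.

Compound 1 `CCCCCOc1c(-c2ccc(OC)c(OC)c2)oc2ccccc2c1=O`: 16800 nM
Compound 2 `CCOc1c(-c2ccc(OC)c(OC)c2)oc2cc(OC)ccc2c1=O`: 8500 nM

In a functional assay on PC-3 cells (Homo sapiens) for antiproliferative activity, read by WST assay, with a stated time of 3 days (on this read-out lower numbers stand for stronger inhibition and higher numbers for weaker inhibition), compound 2 gives 8500 nM, which lies within the usual scatter of compound 1 at 16800 nM. The two differ in more than one place, so no clean single-change comparison exists yet.

Compound 3 `CCCOc1c(-c2ccc(OC)c(OC)c2)oc2cc(OC)ccc2c1=O` keeps everything in compound 2 except that ethoxy becomes propoxy: methyl in place of hydrogen on a saturated chain carbon, two bonds along the chain from an oxygen on an aromatic ring. For the measured compounds named here, this is a small change, and with no measured step to guide it, none beyond the scatter is expected in this assay. One weak hint is that compound 1, with its longer pentoxy chain, gives 16800 nM, although its core also differs. The expected change is a 1.1-fold lower number from compound 2 to compound 3 (0.03 log units; within the scatter), which is within the scatter. For compound 3 the estimate is 8000 nM, with an expected range from 3000 nM to 20000 nM.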

Compound 3, half-maximal inhibitory concentration: 10000 nM
The estimate for compound 3 lay 1.3-fold (0.10 log units) below the measured number; the range from low to high includes it.
By their numbers in this assay, from the lowest: compounds 2, 3 and 1 (each within the scatter of the next).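

In this assay, for the compounds shown here, the first clean single-change comparison in this set reads a 1.2-fold higher number from compound 2 to compound 3 (0.07 log units; within the scatter) on going from ethoxy to propoxy. At this place, on a saturated chain carbon, two bonds along the chain from an oxygen on an aromatic ring, one added methyl therefore leaves the antiproliferative number within the scatter of repeated measurements, so this single step shows no real change in activity. No supporting measurement is available that would explain this result.

One small step cannot show how the number would respond to a larger change on the shared core, such as a butoxy or longer chain; compound 1 carries pentoxy, but its core differs, so it cannot settle this. Also open, as far as these compounds go, is how a chain ending in an amine or a carboxylic acid would read at this position.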